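From 3,4-dichlorophenyl to 4-nitrophenyl on the shared core

The source may hold more compounds than are shown below. What is called first, only, known or untested is meant among the compounds shown, and "the series" means these compounds.

Compound 1 `Cc1ccc(N2CCN(C(=S)SCc3ccc4nc(N)nc(N)c4c3)CC2)cc1` gives 2480 nM
Compound 2 `Nc1nc(N)c2cc(CSC(=S)N3CCN(c4ccc(Cl)c(Cl)c4)CC3)ccc2n1` gives 2370 nM

In a functional assay on MCF7 cells (Homo sapiens) for antiproliferative activity, read by MTT assay, with a stated time of 72 h (a lower number here means a stronger inhibitor, a higher number a weaker inhibitor), compound 2 gives 2370 nM and compound 1 gives 2480 nM. These two values lie within the scatter of each other, so neither compound ranks ahead of the other.

Compound 3 `Nc1nc(N)c2cc(CSC(=S)N3CCN(c4ccc([N+](=O)[O-])cc4)CC3)ccc2n1` has 4-nitrophenyl in place of 3,4-dichlorophenyl on an amine nitrogen in a ring. Among the compounds with values here, only one measured step bears on this change. It put 3,4-dichlorophenyl in place of 4-methylphenyl on the same amine nitrogen, and it is a 1.0-fold lower number from compound 1 to compound 2 (0.02 log units; within the scatter) with no shift beyond the scatter. Within the data shown here, no measured compound carries 4-nitrophenyl, so this single step is thin evidence, and it gives no direction. No step beyond the scatter is therefore expected in this assay, although the range must stay wide. The expected size is a 1.0-fold higher number from compound 2 to compound 3 (0.01 log units; within the scatter) in this estimate. For compound 3 the estimated value is 2400 nM with an expected range from 1000 nM to 5500 nM in this assay.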

Compound 3, half-maximal inhibitory concentration: 1470 nM
Compound 3: middle estimate off by 1.6-fold (0.21 log units), on the high side; the range from low to high includes it.
By their numbers in this assay, from the lowest: compounds 3, 2 and 1 (each within the scatter of the next).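

In this assay, 4-nitrophenyl in place of 3,4-dichlorophenyl on the amine nitrogen in the ring gives a 1.6-fold lower number from compound 2 to compound 3 (0.21 log units; within the scatter), and nitro in place of methyl on the aromatic carbon gives a 1.7-fold lower number from compound 1 to compound 3 (0.23 log units; within the scatter). The earlier pair held only 4-methylphenyl and 3,4-dichlorophenyl; these steps add a third substituted phenyl group, one that brings 2 hydrogen-bond acceptors and a double bond outside the aromatic ring, and both steps still stay within the scatter, so all three groups are alike at this position in this assay. Nothing shown gives a measured reason for these values or says what the nitro group does in the cells.

As far as these compounds go, all three compounds keep a substituted phenyl ring on this nitrogen, so it remains open whether an amine or a carboxylic acid on that ring, or a plain alkyl chain in place of the ring, would produce a step beyond the scatter. The shared core and its link to the six-membered non-aromatic ring are also the same throughout, so these compounds say nothing about a change in either part.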